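Solubility of a ring swap on the shared core

The compounds below may be only part of what the source reports. "The series", "measured", "known", "first", "only" and "open" are said of these compounds alone.

Of the compounds shown here, three built on one core have been measured in a physicochemical assay for solubility, in phosphate buffer, measured as kinetic solubility; on this read-out lower numbers stand for lower solubility and higher numbers for higher solubility. Compound 1 `C/C(=C1/OC(=O)NC1=O)C(c1ccc(-c2ccc3cccc(F)c3c2)[nH]c1=O)C(C)C` gives 17200 nM. Compound 2 `CC(C)C(CC1NC(=O)NC1=O)c1ccc(-c2ccc3cccc(F)c3c2)[nH]c1=O` gives 12300 nM. Compound 3 `CC(C)C(/C=C1/C(=O)NC(=O)N1C)c1ccc(-c2ccc3cccc(F)c3c2)[nH]c1=O` gives 34800 nM, the highest of the three numbers; the nearest is compound 1 and the furthest compound 2, both beyond the scatter.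

Compound 4 `CC(C)C(/C=C1\SC(=O)NC1=O)c1ccc(-c2ccc3cccc(F)c3c2)[nH]c1=O` differs from compound 3 by a group of 8 heavy atoms (4 carbon, 1 nitrogen, 2 oxygen, 1 sulfur; one five-membered non-aromatic ring with 2 hetero atoms) in place of a group of 9 heavy atoms (5 carbon, 2 nitrogen, 2 oxygen; one five-membered non-aromatic ring with 2 hetero atoms), on a saturated chain carbon bound to an aromatic carbon and a saturated chain carbon. The group that enters carries one sulfur and one fewer nitrogen than the group that leaves, with one more hydrogen-bond acceptor.

For the measured compounds named here, the steps that bear on this are those at the same place: a 2.0-fold higher number from compound 1 to compound 3 (0.31 log units; beyond the scatter) and a 2.8-fold higher number from compound 2 to compound 3 (0.45 log units; beyond the scatter). Both run toward compound 3, so compound 3 sits at the high end of what swaps at this position have produced here, and a further swap is expected to move the number in this assay down by a modest amount, a 2.0-fold lower number from compound 3 to compound 4 (0.31 log units; beyond the scatter), into the region of compound 1.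

Compound 4 is therefore expected to give about 17000 nM in this assay, within a range of 8000 nM to 38000 nM.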

Compound 4, solubility: 25600 nM
Compound 4: the middle estimate sits 1.5-fold (0.18 log units) below what was measured, within the range that was stated.
By their numbers in this assay, from the lowest: compounds 2, 1, 4 and 3 (each within the scatter of the next, the first and the last beyond it).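

In this assay, the sulfur-bearing ring on the saturated chain carbon cannot be told apart from either of two earlier rings, although those two stand apart from each other (a 1.4-fold lower number from compound 3 to compound 4 (0.13 log units; within the scatter); a 1.5-fold higher number from compound 1 to compound 4 (0.17 log units; within the scatter)). Only the remaining comparison lies beyond the scatter (a 2.1-fold higher number from compound 2 to compound 4 (0.32 log units; beyond the scatter)), so this swap places compound 4 with compound 1 and compound 3 and apart from compound 2, and the position has now held four different five-membered rings with all the numbers in a narrow band. Nothing measured here explains these numbers. The compounds shown leave open whether a group without a ring at this place, such as a carboxylic acid or an amine on a longer chain, would stay in this band. They also leave open whether the sulfur-bearing ring would give the same picture on another core.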